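Moving the fluorine on the aryl end: compound 2 to compound 3

The compounds below may be only part of what the source reports. "The series", "measured", "known", "first", "only" and "open" are said of these compounds alone.

Two compounds carry numbers in a functional assay on LNCaP cells (Homo sapiens) for cytotoxicity, read by MTT assay, with a stated time of 72 h; a higher number here means a weaker inhibitor, a lower number a stronger inhibitor. Compound 1 `COc1ccc(/C=C/C(=O)/C=C/C2=C(C)CCCC2(C)C)cc1OC` gives 9500 nM. Compound 2 `CC1=C(/C=C/C(=O)/C=C/c2ccccc2F)C(C)(C)CCC1` gives 10700 nM. Among the compounds with values here, the gap between compound 1 and compound 2 lies within the scatter of this assay, so the two are read as alike, and no step between them is computed. Compound 3 `CC1=C(/C=C/C(=O)/C=C/c2ccc(F)cc2)C(C)(C)CCC1` differs from compound 2 by 4-fluorophenyl in place of 2-fluorophenyl on a double-bonded chain carbon bound to a double-bonded chain carbon. Within the data shown here, with no measured step of this kind among the compounds seen, no shift beyond the scatter is expected in this assay in either direction. The step from compound 2 to compound 3 is estimated as a 1.1-fold lower number from compound 2 to compound 3 (0.05 log units; within the scatter). Compound 3 is accordingly expected to give about 9500 nM in this assay, with a range from 4500 nM to 20000 nM.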

Compound 3, half-maximal inhibitory concentration: 7300 nM
Estimate against measurement, compound 3: 1.3-fold (0.11 log units) above; the range from low to high includes it.
By their numbers in this assay, from the lowest: compounds 3, 1 and 2 (each within the scatter of the next).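

In this assay the series now has its first readable step, a 1.5-fold lower number from compound 2 to compound 3 (0.17 log units; within the scatter), and it stays within the scatter. At this position, on a double-bonded chain carbon bound to a double-bonded chain carbon, 4-fluorophenyl and 2-fluorophenyl therefore read as alike, so moving the fluorine on the aryl ring does not separate these two compounds in this assay. Nothing on hand offers an explanation for this result.

Still open, from the compounds shown here alone, is whether any change at this position can move the number beyond the scatter, for example an amine or a carboxylic acid on the aryl ring in place of the fluorine. Also open, going by these compounds, is how a longer chain between the aryl ring and the carbonyl would read against compound 3.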